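Growth inhibition notes: from octyl to 3-chlorophenyl

This account rests on a few compounds, and the source may have more. Where it says the series, first, only, none or still open, it means among the compounds named here.

compound 1 `CCCCCCCCC(=O)N1c2ccccc2CCC1C(=O)Nc1cc(C(F)(F)F)cc(C(F)(F)F)c1` gives 2230 nM
compound 2 `O=C(Nc1ccccc1O)C1CCc2ccccc2N1` gives 2680 nM

Among the measured compounds shown here, in a functional assay on NUGC-3 cells (Homo sapiens) for cytotoxicity, read by sulforhodamine B assay, with a stated time of 72 h (a higher number here means a weaker inhibitor of growth, a lower number a stronger inhibitor of growth), compound 1 stands within the scatter of compound 2, the only other measured compound. Compound 3 `O=C(Nc1cc(C(F)(F)F)cc(C(F)(F)F)c1)C1CCc2ccccc2N1C(=O)c1cccc(Cl)c1` carries 3-chlorophenyl in place of octyl on a carbonyl carbon and has not been measured. For the measured compounds named here, no measured pair tests this change, so no direction can be argued from the data. The expected step of a 1.1-fold higher number from compound 1 to compound 3 (0.05 log units; within the scatter) stays within the scatter. Compound 3 is expected at 2500 nM with 800 nM to 8000 nM as the estimated range.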

Compound 3, concentration for 50% growth inhibition: 560 nM
The estimate for compound 3 lay 4.5-fold (0.65 log units) above the measured number, outside the stated range (below it).
By their numbers in this assay, from the lowest: compound 3; then compounds 1 and 2 (each within the scatter of the next).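

Among the compounds shown here, the carbonyl carbon on the amide-type ring nitrogen is the first place where a single change gives a readable difference. In this assay, 3-chlorophenyl in place of octyl gives a step beyond the scatter (a 4.0-fold lower number from compound 1 to compound 3 (0.60 log units; beyond the scatter)), so this position is not indifferent to its group. Nothing available bears on the reason for this step.

Still open, going by these compounds, is whether the step follows the aromatic ring or the chlorine. Plain phenyl, a shorter alkyl chain such as butyl and an amine-bearing chain at this place lie outside the compounds shown.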